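From dimethylamino to diethylamino in a cell toxicity test

The source may report more compounds than this note shows. Statements on the series, on what has been measured and on what is new or still open speak of the compounds shown alone.

Measured in an ADME assay on L6 cells (Rattus norvegicus) for cytotoxicity, read by resazurin assay, with a stated time of 72 h; on this read-out lower numbers stand for stronger inhibition and higher numbers for weaker inhibition:
- Compound 1 `O=C(NC(=O)c1ccccc1O)c1ccc(-c2ccccc2)cc1`: > 100 ug/mL (a limit)
- Compound 2 `O=C(NC(=O)c1ccccc1O)c1ccc([N+](=O)[O-])cc1`: 53 ug/mL
- Compound 3 `CN(C)c1ccc(C(=O)NC(=O)c2ccccc2O)cc1`: 54 ug/mL

Compound 3 gives 54 ug/mL and compound 2 gives 53 ug/mL, so the two numbers are practically the same, as a 1.0-fold higher number from compound 2 to compound 3 (0.01 log units; within the scatter) shows. Compound 1 stands at > 100 ug/mL, which is a limit of the assay and not a number.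

The next compound, compound 4 `CCN(CC)c1ccc(C(=O)NC(=O)c2ccccc2O)cc1`, keeps the shared core of compound 3 and changes one group: diethylamino in place of dimethylamino on an aromatic carbon. Among the measured compounds shown here, no measured pair makes this exact change, so the closest guide is what other swaps at this same kind of position did. Those steps are an at least 1.8-fold lower number from compound 1 to compound 2 (0.27 log units; that floor lies within the scatter), an at least 1.8-fold lower number from compound 1 to compound 3 (0.26 log units; that floor lies within the scatter) and a 1.0-fold higher number from compound 2 to compound 3 (0.01 log units; within the scatter). None of them is shown to exceed the scatter, even though the groups exchanged differ widely.

A change as modest as adding to the chain on the nitrogen is therefore expected to leave this assay without a clear shift, and the expected step is a 1.0-fold higher number from compound 3 to compound 4 (0.01 log units; within the scatter). Compound 4 is estimated at 55 ug/mL, with an expected range of 28 ug/mL to 100 ug/mL.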

Compound 4, half-maximal inhibitory concentration: 8.2 ug/mL
For compound 4 the middle estimate is 6.7-fold (0.83 log units) above the measured one; the whole stated range lies above it.
By their numbers in this assay, from the lowest: compound 4; then compounds 2 and 3 (each within the scatter of the next). At a limit, above all of these: compound 1.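

The position is not as indifferent as the earlier compounds suggested: in this assay, replacing dimethylamino with diethylamino gives a 6.6-fold lower number from compound 3 to compound 4 (0.82 log units; beyond the scatter), the first step here shown to lie beyond the scatter, and it points towards stronger inhibition of the cells. Nitro and dimethylamino could not be told apart, yet diethylamino stands clearly apart from nitro as well, with a 6.5-fold lower number from compound 2 to compound 4 (0.81 log units; beyond the scatter), so a small change in the chain on the nitrogen matters more here than the exchange of those two very different groups. Against phenyl the result is an at least 12-fold lower number from compound 1 to compound 4 (1.08 log units; beyond the scatter), but that figure is only a floor, as the value for compound 1 is a limit and not a number: the limit of > 100 ug/mL in this assay, at which 1 of the 4 values shown sits.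

From the compounds shown here alone, what remains open is whether the effect keeps growing with a longer chain, such as dipropylamino, or depends on having two ethyl groups, which a monoethylamino group or a piperidine ring would help to test. The compounds shown also give no explanation for why this step is so much larger than the earlier ones.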